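The source may report more compounds than this note shows. Statements on the series, on what has been measured and on what is new or still open speak of the compounds shown alone.

Measured compounds, half-maximal cytotoxic concentration:
- compound 1 `COc1cc(/C=C2\CC/C(=C\c3ccc([N+](=O)[O-])cc3)C2=O)cc(OC)c1OC`: > 400000 nM, a limit of the assay rather than a number
- compound 2 `COc1cc(/C=C2\CCC/C(=C\c3ccc([N+](=O)[O-])cc3)C2=O)ccc1O`: 171000 nM
- compound 3 `COc1ccc(/C=C2\CCC/C(=C\c3ccc([N+](=O)[O-])cc3)C2=O)cc1OC`: 95000 nM

In a functional assay on HPLF cells (Homo sapiens) for cytotoxicity (on this read-out higher numbers stand for lower toxicity in this test and lower numbers for higher toxicity in this test), compound 2 holds the highest of the two numbers obtained. Its nearest neighbour is compound 3, and the step of a 1.8-fold lower number from compound 2 to compound 3 (0.26 log units; within the scatter) stays within the usual scatter, so the two are not separated. Compound 1 sits at a limit, (the limit of > 400000 nM in this assay, at which 1 of the 3 values shown sits), and gives no number to compare.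

Compound 4 `O=C1/C(=C/c2ccc(Cl)cc2)CCC/C1=C\c1ccc([N+](=O)[O-])cc1` is not yet measured. Relative to compound 2 the change is 4-chlorophenyl in place of 4-hydroxy-3-methoxyphenyl on a double-bonded chain carbon bound to a double-bonded ring carbon. For the measured compounds named here, the only measured step, the methylation from compound 2 to compound 3, touches the same ring but is a far smaller alteration and produced no movement beyond the scatter. Going by the values given here, no measured step exchanges the whole aryl group, so the data give little guidance on the size or direction of the effect. Compound 4 is expected to give 120000 nM in this assay, with a range of 40000 nM to 350000 nM. This estimate corresponds to an expected 1.4-fold lower number from compound 2 to compound 4 (0.15 log units; within the scatter), which may well fall within the scatter.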

Compound 4, half-maximal cytotoxic concentration: 332000 nM
Beside the measured number, compound 4's estimate is 2.8-fold (0.44 log units) below it; measured number inside the range.
By their numbers in this assay, from the lowest: compounds 3, 2 and 4 (each within the scatter of the next, the first and the last beyond it). At a limit, above all of these: compound 1.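

Replacing the whole aryl group on a double-bonded chain carbon bound to a double-bonded ring carbon is a much larger change at this position than methylating an oxygen, yet it gives no separable movement in this assay (a 1.9-fold higher number from compound 2 to compound 4 (0.29 log units; within the scatter)). The earlier step (a 1.8-fold lower number from compound 2 to compound 3 (0.26 log units; within the scatter)) altered only one oxygen, whereas 4-chlorophenyl brings 0 hydrogen-bond donors and 0 hydrogen-bond acceptors, so the donor and acceptors of 4-hydroxy-3-methoxyphenyl are not needed to stay within the scatter of compound 2. Even so, compound 3 (95000 nM) and compound 4 (332000 nM) lie beyond the scatter of each other, which shows that the aryl group at this position can shift the number, with compound 2 not separated from either.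

It remains open how an amine or a carboxylic acid in place of 4-chlorophenyl would read in this assay, and whether the chlorine itself contributes, since an unsubstituted phenyl is not among the compounds shown. Compound 1 remains a limit and not a number, and it differs from compound 2 in more than one place, so the top of the series stays unplaced: the limit of > 400000 nM in this assay, at which 1 of the 4 values shown sits.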